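Working notes on the series: step from compound 3 to compound 4

The source may report more compounds than this note shows. Statements on the series, on what has been measured and on what is new or still open speak of the compounds shown alone.

Measured values in an assay on isolated protein for displacement of a labelled ligand from melanin-concentrating hormone receptor 1 (Homo sapiens); on this read-out higher numbers stand for weaker inhibition and lower numbers for stronger inhibition:
compound 1 `CCCc1cc(N)c2cc(NC(=O)/C=C/c3ccc(Cl)cc3)ccc2n1` gives 6 nM
compound 2 `CCCc1cc(N)c2cc(NC(=O)c3ccc(-c4ccc(Cl)cc4)cc3)ccc2n1` gives 0.7 nM
compound 3 `CCCc1cc(N)c2cc(NC(=O)/C=C/c3ccc(SC)cc3)ccc2n1` gives 9 nM

Compound 3 holds the highest of the three numbers in this assay. Its nearest neighbour is compound 1, and the pair lies within the scatter, so no order between them is claimed. Its furthest neighbour is compound 2, whose value lies beyond the scatter from that of compound 3.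

Compound 4 `CCCc1cc(N)c2cc(NC(=O)/C=C/c3ccc(C(C)C)cc3)ccc2n1` differs from compound 3 in one place: isopropyl in place of methylsulfanyl on an aromatic carbon. The group sits on an aromatic carbon of a six-membered aromatic ring of carbon only, para to a large group.

Within the data shown here, only one measured step touches that position: a 1.5-fold higher number from compound 1 to compound 3 (0.18 log units; within the scatter). There, exchanging one substituent for another at the same carbon moved the number within the scatter. Among the measured compounds shown here, no measured compound carries isopropyl at that carbon, so the step is read by analogy to that single exchange, and no step beyond the scatter is expected in this assay, in either direction.

Compound 4 is therefore estimated at 8 nM, with a range from 3 nM to 25 nM. The estimate for compound 4 implies a step of a 1.1-fold lower number from compound 3 to compound 4 (0.05 log units; within the scatter), expected to fall within the scatter.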

Compound 4, half-maximal inhibitory concentration: 2.9 nM
The estimate for compound 4 lay 2.8-fold (0.44 log units) above the measured number; measured number below the stated range.
By their numbers in this assay, from the lowest: compound 2; then compound 4; then compounds 1 and 3 (each within the scatter of the next).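

At the aromatic carbon para to a large group, this assay now separates substituents: isopropyl in place of methylsulfanyl gives a 3.1-fold lower number from compound 3 to compound 4 (0.49 log units; beyond the scatter) and isopropyl in place of chloro gives a 2.1-fold lower number from compound 1 to compound 4 (0.32 log units; beyond the scatter), both modest but beyond the scatter, whereas the earlier exchange of methylsulfanyl for chloro stayed within it. Among the three groups read at this carbon, isopropyl carries the lowest number, while chloro and methylsulfanyl remain unordered. Nothing on hand explains the movement at this carbon.

As far as these compounds go, whether the lower number is particular to isopropyl or also extends to tert-butyl, cyclopropyl or a longer chain remains open, as does the reading for an amine or a carboxylic acid at the same carbon. Also open, from the compounds shown here alone, is whether isopropyl would lower the number on the side chain of compound 2, which differs from these compounds in more than one place.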